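This account rests on a few compounds, and the source may have more. Where it says the series, first, only, none or still open, it means among the compounds named here.

Within the data shown here, compound 2 `CC[C@H](C)[C@H](N)CN(C(=O)[C@@H]1C[C@H]1c1ccc(Cl)cc1)c1ccc(-c2ccccc2)cc1` has the higher of the two numbers measured so far: in a functional assay for agonist activity at G protein-coupled receptor 88 (Homo sapiens), read by HTRF and cAMP accumulation (on this read-out lower numbers stand for an effect already at smaller amounts and higher numbers for an effect only at larger amounts of compound), compound 2 gives 4300 nM, while compound 1 `CC[C@@H](C)[C@H](N)CN(C(=O)[C@@H]1C[C@H]1c1ccccc1)c1ccc(-c2ccccc2)cc1` gives 1.4 nM; the two differ in more than one place, so their gap is not traced to a single change. Compound 3 `CC[C@H](C)[C@H](N)CN(C(=O)[C@@H]1C[C@H]1c1ccccc1Cl)c1ccc(-c2ccccc2)cc1` has the same atoms as compound 2, joined differently: 2-chlorophenyl in place of 4-chlorophenyl on a saturated ring carbon. Among the measured compounds shown here, no measured pair shows what such a move does here, so the expected step from compound 2 to compound 3 is an uncertain a 2.9-fold lower number from compound 2 to compound 3 (0.46 log units; beyond the scatter), guessed as a modest gain. For compound 3 the estimate is 1500 nM, within 200 nM to 10000 nM.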

Compound 3, half-maximal effective concentration: > 25000 nM
Compound 3 ended at the assay's limit; the forecaster's own chance of this, stated with the estimate: 10%; middle value at least 16-fold (1.22 log units) from the limit.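

Putting 2-chlorophenyl in place of 4-chlorophenyl on this saturated ring carbon gives an at least 5.8-fold higher number from compound 2 to compound 3 (0.76 log units; beyond the scatter) in this assay. Among these compounds, this is the first measured sign that, with the same atoms, the place of the chlorine on the phenyl ring matters here. Compound 3 stands at a limit of the assay and not at a number, so the real step may be larger: the limit of > 25000 nM in this assay, at which 1 of the 3 values shown sits.

Still open, from the compounds shown here alone, is what a plain phenyl would do on the exact core of compound 2. Also open, going by these compounds, is whether fluorine or methoxy in place of the chlorine would be tolerated.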